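From Benzyl Ester to Free Acid: Expecting Compound 4

This account rests on a few compounds, and the source may have more. Where it says the series, first, only, none or still open, it means among the compounds named here.

Compound 1 `NCCCC[C@H](NC(=O)CN(c1nc(Cl)nc2[nH]cnc12)C1CC1)C(=O)O`: 16.4%
Compound 2 `O=C(O)C[C@H](NC(=O)CN(c1nc(Cl)nc2[nH]cnc12)C1CC1)C(=O)O`: 22%
Compound 3 `NC(=O)CC[C@H](NC(=O)CN(c1nc(Cl)nc2[nH]cnc12)C1CC1)C(=O)OCc1ccccc1`: 36%

In a functional assay on the whole organism (Tail, strain ICR) with Mus musculus as the target, in the tail flick test, with a stated time of 120 min, at a dose of 25 umol/kg by the oral route (a lower number here means a weaker effect, a higher number a stronger effect of the compound at the dose given), compound 3 gives the highest of the three numbers, and its gaps to compound 2 and to compound 1 both lie beyond the scatter. Compound 4 `NC(=O)CC[C@H](NC(=O)CN(c1nc(Cl)nc2[nH]cnc12)C1CC1)C(=O)O` differs from compound 3 by hydrogen in place of benzyl on an oxygen next to a carbonyl group. Going by the values given here, the only measured step, a number 5.6 percentage points higher from compound 1 to compound 2 (within the scatter), changes a side chain and not this oxygen, so no measured step bears directly on the change. Both compounds carrying a carboxy group, compound 1 with 16.4% and compound 2 with 22%, sit clearly lower than compound 3. Compound 4 is therefore expected to drop, a step of a number 14 percentage points lower from compound 3 to compound 4 (beyond the scatter) beyond the scatter. Compound 4 is estimated at 22%, between 10% and 34%.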

Compound 4, a percentage reported as activity, at one dose (the size of the read-out at that dose, not a potency): 17.8%
Compound 4: the middle estimate sits 4.2 percentage points above what was measured; the measured number falls inside the stated range.
By their numbers in this assay, from the lowest: compounds 1, 4 and 2 (each within the scatter of the next); then compound 3.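

In this assay, going by these compounds alone, hydrogen in place of benzyl on the oxygen next to a carbonyl group gives a number 18.2 percentage points lower from compound 3 to compound 4 (beyond the scatter) and is the first direct reading of this change. With hydrogen on that oxygen, the side chain changes give a number 4.2 percentage points lower from compound 2 to compound 4 (within the scatter) and a number 1.4 percentage points higher from compound 1 to compound 4 (within the scatter) and do not separate these compounds. Nothing available explains the step from benzyl to hydrogen. The compounds shown leave open whether a methyl ester or an ethyl ester at this oxygen would keep the higher number. They also leave open whether a benzyl ester gives the same step with the other side chains.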